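Ring Stereocentre Inversion in a Serine-Phosphate Ester Series

This account rests on a few compounds, and the source may have more. Where it says the series, first, only, none or still open, it means among the compounds named here.

In an assay on HEK293-A cells with putative P2Y purinoceptor 10 (Mus musculus) as the target, with a stated time of 1.5 h (a lower number here means a smaller maximal response, a higher number a larger maximal response), three compounds have been examined so far. Compound 1 `N[C@@H](COP(=O)(O)O[C@@H]1CCCO[C@@H]1COC(=O)CCc1ccccc1OCc1cccc(Oc2ccccc2)c1)C(=O)O` is reported as "not active" (no number reported), and compound 3 `N[C@@H](COP(=O)(O)OC[C@H]1OCCC[C@H]1OC(=O)CCc1ccc(OCc2cccc(Oc3ccccc3)c2)cc1)C(=O)O` likewise comes out as "not active" (no number reported). Compound 2 `CCCCCCCCCCCOc1ccccc1CCC(=O)OC[C@H]1OCCC[C@H]1OP(=O)(O)OC[C@H](N)C(=O)O` is the only one of the three with a numerical read-out, giving 0.0038 in this assay, a maximal response that is itself very small against the reference agonist. Compound 2 therefore stands as the single quantified entry, and the two others give no number at all.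

Compound 4 `CCCCCCCCCCCOc1ccccc1CCC(=O)OC[C@H]1OCCC[C@@H]1OP(=O)(O)OC[C@H](N)C(=O)O` is the next compound to be measured in this assay. It differs from compound 2 as follows: the two compounds have the same atoms and bonds; at least one stereo element is drawn with a configuration in one of them and without one in the other: 1 of 4 stereo elements differ; a stereocentre at a saturated ring carbon is drawn R in compound 2 and S in compound 4

Among the compounds with values here, no step between measured compounds is available, so the expectation rests on compound 2 alone. Since compound 2 gives only 0.0038 and the other two compounds give no number, there is no indication that a change of one ring stereocentre would raise the maximal response beyond the usual scatter; the step from compound 2 to compound 4 is expected to be a number 0.0062 higher from compound 2 to compound 4 (within the scatter), that is, essentially none. Compound 4 is thus estimated to give 0.01 in this assay, with a range from 0 to 0.1.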

Compound 4, intrinsic activity: the largest response reached, as a fraction of the reference agonist's: 0.002
Estimate against measurement, compound 4: 0.0080 above, within the range that was stated.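

Inverting the stereocentre at the saturated ring carbon gives the series its first readable step: in this assay, the change is a number 0.0018 lower from compound 2 to compound 4 (within the scatter). Compound 2 and compound 4 cannot be told apart by their maximal response, so with this side chain and all else held the same, the drawn configuration at this ring carbon makes no measurable difference, a point that a single quantified compound could not establish. The comparison carries one caveat about how the two structures are drawn: the fact that one of compounds 2 and 4 is drawn with a defined configuration and the other without, at the place where they differ

On these data alone, the step comes from two compounds with very small responses, and it remains open whether this ring carbon would matter equally in a compound with a clearly larger maximal response. Also open, as far as these compounds go, is whether the same inversion would stay within the scatter if the long alkyl ether chain were replaced by a shorter chain, or ended in a carboxylic acid or an amine.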